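Nitro for methoxy on the benzyl group: next step

The source may hold more compounds than are shown below. What is called first, only, known or untested is meant among the compounds shown, and "the series" means these compounds.

Measured so far:
- Compound 1 `COc1ccc(Cn2cc(CO/N=C/c3c(-c4ccc(C)cc4)nc4ccc(Br)cn34)nn2)cc1` gives 40 mg/kg in a functional assay on the whole organism (strain NMRI) with Mus musculus as the target, with a stated time of 4 h; on this read-out higher numbers stand for an effect only at larger amounts of compound and lower numbers for an effect already at smaller amounts.
- Compound 2 `COc1ccc(Cn2cc(CO/N=C/c3c(-c4ccccc4)nc4ccc(Br)cn34)nn2)cc1` gives 40 mg/kg in this assay.

Compound 2 stands level with compound 1 at the digits shown; the step of no change at the digits printed from compound 1 to compound 2 (within the scatter) lies within the scatter. Compound 3 `O=[N+]([O-])c1ccc(Cn2cc(CO/N=C/c3c(-c4ccccc4)nc4ccc(Br)cn34)nn2)cc1` differs from compound 2 by nitro in place of methoxy on an aromatic carbon. For the measured compounds named here, no measured step touches this position; the only step known, no change at the digits printed from compound 1 to compound 2 (within the scatter), concerns the other aryl ring and was flat, so it gives no direction here. Accordingly no change beyond the scatter is expected, no change at the digits printed from compound 2 to compound 3 (within the scatter). Compound 3 is estimated at 40 mg/kg in this assay, within 20 mg/kg to 80 mg/kg.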

Compound 3, minimum effective dose: 40 mg/kg
Compound 3: the middle estimate sits on the measured number at the digits printed; the range from low to high includes it.
By their numbers in this assay, from the lowest: compounds 1, 2 and 3 (each within the scatter of the next).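

In this assay, the exchange of 4-methoxybenzyl for 4-nitrobenzyl reads as no change at the digits printed from compound 2 to compound 3 (within the scatter), which gives this position its first measured step. For the compounds shown here, the two groups named here cannot be told apart on this read-out, and across the three compounds, both single-place steps, on the other aryl ring and on the benzyl group, are flat, with no compound going against this. No available evidence accounts for this flat reading.

Open, from the compounds shown here alone, is whether an amine or a carboxylic acid in place of nitro would give a step beyond the scatter. Also open, going by these compounds, is whether a longer chain between the ring and that group would do so.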